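The compounds below may be only part of what the source reports. "The series", "measured", "known", "first", "only" and "open" are said of these compounds alone.

Compound 1 `CS/C(=N\C(=O)c1ccno1)NC(=O)c1ccno1` is the starting point of this step. In a functional assay on HT-29 cells (Homo sapiens) for cytotoxicity, read by MTT assay, with a stated time of 72 h (on this read-out lower numbers stand for stronger inhibition of growth and higher numbers for weaker inhibition of growth), compound 1 gives > 100000 nM, which is a limit of the assay. Two further compounds stand in the same way. Compound 2 `CS/C(=N\C(=O)c1ccco1)NC(=O)c1ccco1` gives in this assay > 100000 nM, again a limit. Compound 3 `C[Se]/C(=N\C(=O)c1cccs1)NC(=O)c1cccs1` gives in this assay > 100000 nM, also a limit. Within the data shown here, compound 1 thus shares its standing with every value shown, all sitting at the limit of > 100000 nM in this assay, at which 3 of the 3 values shown sit, and no step between measured compounds can be read from these three.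

Compound 4 `O=C(/N=C(/NC(=O)c1ccno1)[Se]Cc1ccccc1)c1ccno1` has not yet been measured in this assay. It differs from compound 1 in one place: a group of 8 heavy atoms (7 carbon, 1 selenium; one six-membered aromatic ring of carbon only) in place of a group of 2 heavy atoms (1 carbon, 1 sulfur; no ring), on a carbon with a double bond to nitrogen. Among the measured compounds shown here, with no measured step to lean on, no direction can be drawn from the data, and the step in this assay is expected to stay within the scatter. The step is expected to be a number no higher from compound 1 to compound 4 (the limit leaves the size open). Compound 4 is therefore expected to give about 100000 nM in this assay, within a range from 30000 nM to 300000 nM, most likely again as a limit.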

Compound 4, concentration for total growth inhibition: > 100000 nM
Compound 4: only a limit was reported (the forecaster's own chance of this, stated with the estimate: 70%); the middle value lies on the limit itself.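

Compound 1 and compound 4 both stand only as limits in this assay, so no step between them can be read: the limit of > 100000 nM in this assay, at which 4 of the 4 values shown sit.

The compounds shown leave open what actual growth-inhibiting concentration any of them has, and whether the group entering in compound 4 in place of methylsulfanyl changes the result in this assay at all.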